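Oxamate series: second oxamate group in place of methoxy

The source may hold more compounds than are shown below. What is called first, only, known or untested is meant among the compounds shown, and "the series" means these compounds.

Measured compounds in a functional assay on the whole organism (strain Sprague-Dawley CD) for inhibition, with Rattus norvegicus as the target, read by paw edema, at a dose of 30 mg/kg by the oral route; a lower number here means a weaker effect, a higher number a stronger effect of the compound at the dose given:
compound 1 `CCOC(=O)C(=O)Nc1cccccc1=O` gives 79%
compound 2 `CCOC(=O)C(=O)Nc1ccccc(N(C)S(=O)(=O)c2ccc(C)cc2)c1=O` gives 3%
compound 3 `CCOC(=O)C(=O)Nc1ccc(OC)ccc1=O` gives 31%

Compound 3 stands second highest of the three numbers in this assay. Compound 1 shows the high value and compound 2 the low one; the gap from compound 3 to compound 2 is beyond the scatter, as is the gap to compound 1. Within the data shown here, the one step from a single change on the core is a number 48 percentage points lower from compound 1 to compound 3 (beyond the scatter), a large drop on adding methoxy to an aromatic carbon of the seven-membered ring.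

Compound 4 `CCOC(=O)C(=O)Nc1ccc(NC(=O)C(=O)OCC)c(=O)cc1` differs from compound 3 by ((ethoxycarbonyl)carbonyl)amino in place of methoxy on an aromatic carbon. Among the measured compounds shown here, no measured step exchanges one ring substituent for another, so the step of a number 48 percentage points lower from compound 1 to compound 3 (beyond the scatter) bears only in so far as it shows that a group on that ring lowers the number, and compound 2, with a larger group, shows the lowest value. A further fall in this assay is therefore expected for compound 4, though of uncertain size, the estimated step being a number 13 percentage points lower from compound 3 to compound 4 (beyond the scatter). For compound 4 the estimate is 18%, within 0% to 48%.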

Compound 4, a percentage reported as inhibition, in the whole organism at one dose (the size of the read-out at that dose, not a potency): 61%
The estimate for compound 4 lay 43 percentage points below the measured number, and the stated range ends below it.
By their numbers in this assay, from the lowest: compound 2; then compound 3; then compound 4; then compound 1.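

In this assay, the step of a number 30 percentage points higher from compound 3 to compound 4 (beyond the scatter) shows that on this aromatic carbon the larger ((ethoxycarbonyl)carbonyl)amino group, with 8 heavy atoms against 2 in methoxy, does not give the lower number, so the count of heavy atoms alone does not order these two compounds. A group at this place still costs something, as the step of a number 18 percentage points lower from compound 1 to compound 4 (beyond the scatter) shows, and hydrogen keeps the highest number of the three compounds that differ only here. The data at hand give no reason for the difference between methoxy and the larger group.

Open, as far as these compounds go, is whether the higher number belongs to the whole ((ethoxycarbonyl)carbonyl)amino group or to its amino nitrogen alone. A plain amine, or a carboxylic acid in place of the ethyl ester, at the same place would separate these two readings.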